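The source may hold more compounds than are shown below. What is called first, only, known or untested is meant among the compounds shown, and "the series" means these compounds.

Measured in a functional assay on U-937 cells (Homo sapiens) for antiproliferative activity, read by MTT assay, with a stated time of 24 h; on this read-out lower numbers stand for stronger inhibition of growth and higher numbers for weaker inhibition of growth:

- Compound 1 `Cc1ccc(NC(=O)Cc2c[nH]c3ccccc23)cc1NC(=O)c1cnoc1C`: > 30000 nM, a limit
- Compound 2 `Cc1ccc(NC(=O)Nc2cc(Cl)cc(Cl)c2)cc1NC(=O)c1cnoc1C`: > 30000 nM, a limit
- Compound 3 `Cc1cc(NC(=O)Nc2cccc(Cl)c2)ccc1NC(=O)c1cnoc1C`: > 30000 nM, a limit

None of these three entries is a true number. Each one is a limit of the assay. Compound 3 therefore has no exact position in the series and sits with the other two compounds, at the limit of > 30000 nM in this assay, at which 3 of the 3 values shown sit.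

The next compound to be tested is compound 4 `Cc1cc(NC(=O)Nc2cc(Cl)cc(Cl)c2)ccc1NC(=O)c1cnoc1C`. It is compound 3 with chloro in place of hydrogen on an aromatic carbon, so that 3-chlorophenyl becomes 3,5-dichlorophenyl: chloro in place of hydrogen on an aromatic carbon.

Within the data shown here, no pair of measured compounds shows what such a change does, so the size of the step cannot be read directly from the data. The nearest guide is compound 2, which already carries the 3,5-dichlorophenyl group. In this assay compound 2 gives > 30000 nM, which is again a limit.

On that basis, no step beyond the usual scatter is expected, and growth inhibition should remain weak. The estimated step is a number no higher from compound 3 to compound 4 (the limit leaves the size open). For compound 4 the expected value is 30000 nM, with an estimated range of 12000 nM to 60000 nM.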

Compound 4, concentration for 50% growth inhibition: > 30000 nM
Compound 4 was reported as a limit (the forecaster's own chance of this, stated with the estimate: 85%); the middle value lies on the limit itself.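

No step can be read from compound 3 to compound 4, because neither compound has a true number, only a limit: the limit of > 30000 nM in this assay, at which 4 of the 4 values shown sit.

The compounds shown leave open what the second chloro does to growth inhibition, and which change to the shared core, if any, would give a true number in this assay.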